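The compounds below may be only part of what the source reports. "The series", "measured", "known", "first", "only" and "open" are said of these compounds alone.

Of the compounds shown here, three sharing one core have been tested in a functional assay; on this read-out lower numbers stand for an effect already at smaller amounts and higher numbers for an effect only at larger amounts of compound. Compound 1 `COc1ccc2c(c1)OC(c1cccc([N+](=O)[O-])c1)C(c1ccccc1)C2=O` gives 130000 nM. Compound 2 `COc1ccc2c(c1)OC(c1ccc(Cl)cc1)C(c1ccccc1)C2=O` gives 165000 nM. Compound 3 `CCOc1ccc2c(c1)OC(c1cccc([N+](=O)[O-])c1)C(c1ccccc1)C2=O` gives 193000 nM. The step of a 1.5-fold higher number from compound 1 to compound 3 (0.17 log units; within the scatter) shows that putting a methyl on the chain carbon bound to the aromatic oxygen made no difference beyond the scatter, and the numbers of compound 3 and compound 2 likewise lie within the scatter of each other, so all three compounds sit at about the same level on this read-out.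

Compound 4 `CCOc1ccc2c(c1)OC(c1ccc(Cl)cc1)C(c1ccccc1)C2=O` has not yet been measured. It differs from compound 3 in one place: 4-chlorophenyl in place of 3-nitrophenyl on a saturated ring carbon. The same exchange has been made once before among the measured compounds, and its step was a 1.3-fold higher number from compound 1 to compound 2 (0.10 log units; within the scatter), a shift too small to count. On that basis the expected change in this assay is a 1.2-fold higher number from compound 3 to compound 4 (0.08 log units; within the scatter), nothing beyond the scatter. Compound 4 is therefore estimated at 230000 nM, with a range from 110000 nM to 480000 nM.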

Compound 4, half-maximal effective concentration: 578000 nM
Estimate against measurement, compound 4: 2.5-fold (0.40 log units) below; the whole stated range lies below it.
By their numbers in this assay, from the lowest: compounds 1, 2 and 3 (each within the scatter of the next); then compound 4.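

In this assay, the exchange of 3-nitrophenyl for 4-chlorophenyl on the saturated ring carbon now produces a step beyond the scatter on the core carrying the added methyl, a 3.0-fold higher number from compound 3 to compound 4 (0.48 log units; beyond the scatter), so this position is not indifferent to the change on every core. Even so, this step cannot be firmly separated from the earlier one: the same change on two cores in this assay, a 1.3-fold higher number (0.10 log units; within the scatter) from compound 1 to compound 2 and a 3.0-fold higher number (0.48 log units; beyond the scatter) from compound 3 to compound 4, 2.4-fold (0.37 log units) apart, within the scatter of two such steps. The added methyl likewise now gives a step beyond the scatter when 4-chlorophenyl is present, a 3.5-fold higher number from compound 2 to compound 4 (0.54 log units; beyond the scatter), but the same caution applies: the same change on two cores in this assay, a 1.5-fold higher number (0.17 log units; within the scatter) from compound 1 to compound 3 and a 3.5-fold higher number (0.54 log units; beyond the scatter) from compound 2 to compound 4, 2.4-fold (0.37 log units) apart, within the scatter of two such steps.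

From the compounds shown here alone, whether the two changes truly reinforce each other therefore remains open, as all of this rests on four compounds. Also open, going by these compounds, is how an aminophenyl group on the saturated ring carbon, or a propyl chain on the aromatic oxygen, would read.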